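Swapping One Ring for a Near Twin

The compounds below may be only part of what the source reports. "The series", "measured", "known", "first", "only" and "open" are said of these compounds alone.

Of the compounds shown here, two built on a shared core have been tested in a functional assay on UO-31 cells (Homo sapiens); a lower number here means a stronger inhibitor of growth, a higher number a weaker inhibitor of growth. Compound 1 `COc1cc(CSc2cc(Cl)c(-c3nc(-c4ccc(Cl)cc4)no3)cc2S(=O)(=O)NC(=N)NO)cc(OC)c1OC` gives 3160 nM, the higher of the two numbers recorded so far. Compound 2 `N=C(NO)NS(=O)(=O)c1cc(-c2nc(-c3ccccc3)no2)c(Cl)cc1SCc1ccccc1`, which carries a different set of side groups on the same core, gives 1400 nM in this assay; its number is lower than that of compound 1, and the gap between them is beyond the usual scatter.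

Compound 3 `COc1cc(CSc2cc(Cl)c(-c3nnc(-c4ccc(Cl)cc4)s3)cc2S(=O)(=O)NC(=N)NO)cc(OC)c1OC` has not yet been measured. It differs from compound 1 in a single place: 5-(4-chlorophenyl)-1,3,4-thiadiazol-2-yl in place of 3-(4-chlorophenyl)-1,2,4-oxadiazol-5-yl on an aromatic carbon. The leaving and entering groups match in size and in the counted donors and acceptors, so the change is a modest one. Going by the values given here, no measured pair shows this swap, and the expectation rests on the structural change alone. The estimated step from compound 1 to compound 3 is a 1.3-fold lower number from compound 1 to compound 3 (0.10 log units; within the scatter), expected to fall within the scatter, with no firm direction. For compound 3 the estimated value in this assay is 2500 nM, with a range from 800 nM to 8000 nM.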

Compound 3, concentration for 50% growth inhibition: 44700 nM
For compound 3 the middle estimate is 18-fold (1.25 log units) below the measured one, and the stated range ends below it.
By their numbers in this assay, from the lowest: compound 2; then compound 1; then compound 3.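

In this assay, placing 5-(4-chlorophenyl)-1,3,4-thiadiazol-2-yl where 3-(4-chlorophenyl)-1,2,4-oxadiazol-5-yl stood gives a 14-fold higher number from compound 1 to compound 3 (1.15 log units; beyond the scatter) and shows that this position on an aromatic carbon is far from indifferent to which five-membered ring it carries. The two groups have the same counts of heavy atoms, hydrogen-bond donors and hydrogen-bond acceptors, so in this pair those counts did not predict how well the compound inhibits growth. What separates the two groups is a sulfur in place of an oxygen and a different arrangement of the ring atoms, and no measurement at hand accounts for the size of this step.

The compounds shown leave open whether the same swap would produce a comparable step on the side groups of compound 2. They also leave open how 5-(4-chlorophenyl)-1,3,4-oxadiazol-2-yl would compare, a group that keeps the oxygen of the leaving ring while taking the ring-atom arrangement of the entering one, and so could help separate the contribution of the sulfur from that of the arrangement.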